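Debenzylation on a Thiophene Scaffold: Two Regioisomeric Series

The source may report more compounds than this note shows. Statements on the series, on what has been measured and on what is new or still open speak of the compounds shown alone.

Measured compounds:
Compound 1, `CCOC(=O)c1cc(-c2cc(OC)c(OC)c(OC)c2)c(-c2ccc(OC)c(OCc3ccccc3)c2)s1`: > 100000 nM
Compound 2, `CCOC(=O)c1cc(-c2cc(OC)c(OC)c(OC)c2)c(-c2ccc(OC)c(O)c2)s1`: 1250 nM
Compound 3, `CCOC(=O)c1cc(-c2ccc(OC)c(OCc3ccccc3)c2)c(-c2cc(OC)c(OC)c(OC)c2)s1`: > 100000 nM

This account concerns a functional assay on KB cells (Homo sapiens) for antiproliferative activity, read by MTT assay, with a stated time of 72 h; a higher number here means a weaker inhibitor, a lower number a stronger inhibitor. Compound 1 reaches only the limit of this assay, at > 100000 nM. Compound 2 carries hydrogen in place of benzyl on an oxygen on an aromatic ring, and the consequence is an at least 80-fold lower number from compound 1 to compound 2 (1.90 log units; beyond the scatter). Two of the three values sit at the limit of > 100000 nM in this assay, at which 2 of the 3 values shown sit, so the true size of that step is not pinned down, only its lower bound.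

Compound 3 shares all atoms with compound 1 but joins them differently; the difference between the two cores is not broken down here. In this assay compound 3 gives only the limit > 100000 nM.

Compound 4, `CCOC(=O)c1cc(-c2ccc(OC)c(O)c2)c(-c2cc(OC)c(OC)c(OC)c2)s1`, has not yet been measured. It relates to compound 3 by hydrogen in place of benzyl on an oxygen on an aromatic ring, which is the same change that turns compound 1 into compound 2, occurring twice among these compounds. The expectation is that compound 4 will also show a marked gain, with an estimated step of an at least 40-fold lower number from compound 3 to compound 4 (1.60 log units; beyond the scatter), because the matching change gave an at least 80-fold lower number from compound 1 to compound 2 (1.90 log units; beyond the scatter). Compound 4 is therefore estimated at 2500 nM in this assay, with a plausible range from 300 nM to 30000 nM. Whether the regioisomeric core responds alike is the open question, and the measurement will decide it.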

Compound 4, half-maximal inhibitory concentration: > 100000 nM
Compound 4 was reported as a limit (the forecaster's own chance of this, stated with the estimate: 20%); at least 40-fold (1.60 log units) between middle value and limit.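

In this assay compound 4 gives > 100000 nM, which is a limit and not a number. Going by these compounds alone, compound 3 also stands at a limit, so no step between compound 3 and compound 4 can be read: the limit of > 100000 nM in this assay, at which 3 of the 4 values shown sit.

The compounds shown leave open whether hydrogen in place of benzyl on an oxygen on an aromatic ring changes activity at all on the core of compound 3.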